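Replacing an Aromatic Amine with a Nitro Group

The source may hold more compounds than are shown below. What is called first, only, known or untested is meant among the compounds shown, and "the series" means these compounds.

Measured so far:
Compound 1 `CN1CCN(c2ccc(NC(=O)c3cc4cc(NC(=O)CCl)ccc4n3Cc3ccc(C(F)(F)F)cc3)cc2)CC1`, 2990 nM
Compound 2 `CN1CCN(c2ccc(NC(=O)c3cc4cc(N)ccc4n3Cc3ccc(C(F)(F)F)cc3)cc2)CC1`, "not active" (no number reported)

Compound 1 and compound 2 share one core and differ only in what sits on that core. In a functional assay on RAW264.7 cells (Mus musculus) for inhibition, read by ELISA, with stated times of 30 min and 24 h (on this read-out lower numbers stand for stronger inhibition and higher numbers for weaker inhibition), compound 1 gives 2990 nM, whereas compound 2 is reported in this assay as "not active" (no number reported), so no number stands beside it. Compound 2 therefore has no place on the numerical scale here; it is simply the compound for which the read-out failed to register a measurable effect.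

The step now followed leads from compound 2 to compound 3 `CN1CCN(c2ccc(NC(=O)c3cc4cc([N+](=O)[O-])ccc4n3Cc3ccc(C(F)(F)F)cc3)cc2)CC1`. The change is counted as nitro in place of amino on an aromatic carbon. The amino group goes and a nitro group arrives, on an aromatic carbon of the six-membered carbon-only ring that is part of the fused two-ring system.

Among the measured compounds shown here, with no measured step of this kind to lean on, the expectation is modest: in this assay the move from an amine to a nitro group is expected to produce no shift beyond the usual scatter, leaving compound 3 weak as well. Compound 3 is estimated at 15000 nM, within a range of 4000 nM to 60000 nM.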

Compound 3, half-maximal inhibitory concentration: 5090 nM
Compound 3: middle estimate off by 2.9-fold (0.47 log units), on the high side, within the range that was stated.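

In this assay compound 3 gives 5090 nM, so this aromatic carbon can carry a group other than ((chloromethyl)carbonyl)amino and still give a measurable number, while the amino group of compound 2 gives none; with no number for compound 2, the change from amino to nitro cannot be read as a step of any size. The exchange of ((chloromethyl)carbonyl)amino for nitro gives a 1.7-fold higher number from compound 1 to compound 3 (0.23 log units; within the scatter), so this assay does not separate these two groups, even though they differ in size and in what they are built from. Nothing measured here offers a reason why the compound with the amino group stands apart from the other two.

What remains open is how narrow the requirement at this carbon is, since only three groups are shown there and two of them cannot be told apart. A nitrile, a methoxy group or a plain acetylamino group in the same place would show whether the measurable result extends beyond nitro and ((chloromethyl)carbonyl)amino, and whether any group can bring the number much lower.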